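The source may report more compounds than this note shows. Statements on the series, on what has been measured and on what is new or still open speak of the compounds shown alone.

In a functional assay on NCI-H460 cells (Homo sapiens) for cytotoxicity, read by resazurin assay, with a stated time of 72 h (a higher number here means a weaker inhibitor, a lower number a stronger inhibitor), compound 1 (`COc1cc(/C=C/C(=O)OCCCCCCO[N+](=O)[O-])ccc1O`) gives > 50000 nM, which is a limit of the assay and not a number. Two relatives with shorter chains do give numbers: compound 2 (`COc1cc(/C=C/C(=O)OCCCCCO[N+](=O)[O-])ccc1O`) reads 12300 nM and compound 3 (`COc1cc(/C=C/C(=O)OCCCO[N+](=O)[O-])ccc1O`) reads 29000 nM.

The next compound changes a different part of the molecule. Compound 4 (`COc1cc(/C=C/C(=O)OCCCCCCO[N+](=O)[O-])ccc1OCCCCCCO[N+](=O)[O-]`) differs from compound 1 at one place: 6-(nitrooxy)hexyl in place of hydrogen on an oxygen on an aromatic ring. In words, 6-(nitrooxy)hexyl stands in place of hydrogen on an oxygen on an aromatic ring.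

Three measured steps are available, and all of them alter only the length of the chain that ends in nitrooxy: an at least 4.0-fold lower number from compound 1 to compound 2 (0.60 log units; beyond the scatter), an at least 1.7-fold lower number from compound 1 to compound 3 (0.23 log units; that floor lies within the scatter) and a 2.4-fold higher number from compound 2 to compound 3 (0.37 log units; beyond the scatter). None of them touches the aromatic oxygen, so they bear on this change only indirectly, as a guide to the size of steps in this small set, and that size is modest. The direction of the new step is therefore uncertain, and compound 4 may well stay at the limit in this assay. The expected change, if a number is obtained, is a modest one, estimated as an at least 1.6-fold lower number from compound 1 to compound 4 (0.22 log units; that floor lies within the scatter). For compound 4 the estimated value is 30000 nM, with an expected range from 8000 nM to 50000 nM.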

Compound 4, half-maximal inhibitory concentration: > 50000 nM
Compound 4: a limit, no number; the forecaster's own chance of this, stated with the estimate: 45%; at least 1.6-fold (0.22 log units) between middle value and limit.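

In this assay compound 4 gives > 50000 nM, which is a limit of the assay and not a number. Compound 1 also sits at a limit, so no step from compound 1 to compound 4 can be read: the limit of > 50000 nM in this assay, at which 2 of the 4 values shown sit.

From the compounds shown here alone, whether 6-(nitrooxy)hexyl in place of hydrogen on the aromatic oxygen changes the cytotoxicity at all, and in which direction, stays open.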